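The source may report more compounds than this note shows. Statements on the series, on what has been measured and on what is new or still open speak of the compounds shown alone.

Measured so far in a functional assay on Huh-7 cells (Homo sapiens) for inhibition, read by sulforhodamine B assay, with a stated time of 72 h; on this read-out higher numbers stand for weaker inhibition and lower numbers for stronger inhibition:

- compound 1, `O=C(/C=C/c1cn(-c2ccccc2)nc1-c1ccsc1)c1ccccc1`, gives 4700 nM
- compound 2, `COc1cc(OC)c(C(=O)/C=C/c2cn(-c3ccccc3)nc2-c2ccsc2)c(OC)c1`, gives 6100 nM
- compound 3, `O=C(/C=C/c1cn(-c2ccccc2)nc1-c1cccnc1)c1ccccc1`, gives 2300 nM

Compound 4, `COc1cc(OC)c(C(=O)/C=C/c2cn(-c3ccccc3)nc2-c2cccnc2)c(OC)c1`, has not yet been measured in this assay.

Compound 1 and compound 3 share a core and differ in one place: pyridin-3-yl in place of thiophen-3-yl on an aromatic carbon. The step that this change made in this assay is a 2.0-fold lower number from compound 1 to compound 3 (0.31 log units; beyond the scatter).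

Compound 2 carries a different core from compound 1; how the two cores differ is not broken down here. In this assay the value of compound 2 lies within the usual scatter of the value of compound 1, so no order between these two can be read from the data. The value of compound 2 does lie beyond the scatter from the value of compound 3.

Compound 4 stands to compound 2 as compound 3 stands to compound 1: pyridin-3-yl in place of thiophen-3-yl on an aromatic carbon. The surroundings of the exchanged group are described in the same words for both pairs, so this is the same change on a different core.

Among the compounds with values here, with only one measured instance of the change to rest on, the step from compound 2 to compound 4 in this assay is expected to be about a 2.0-fold lower number from compound 2 to compound 4 (0.31 log units; beyond the scatter), in line with a 2.0-fold lower number from compound 1 to compound 3 (0.31 log units; beyond the scatter). On that basis compound 4 is estimated at 3000 nM in this assay, with a plausible range from 1500 nM to 6500 nM.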

Compound 4, half-maximal inhibitory concentration: 500 nM
Beside the measured number, compound 4's estimate is 6.0-fold (0.78 log units) above it; measured number below the stated range.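

In this assay, pyridin-3-yl in place of thiophen-3-yl on the core of compound 2 gives a large step, a 12-fold lower number from compound 2 to compound 4 (1.09 log units; beyond the scatter). The direction of the change is the same on both cores, but its size does not carry over from one to the other, so a step measured on one core is a poor guide to the size of the step on the other: the same change on two cores in this assay, a 2.0-fold lower number (0.31 log units; beyond the scatter) from compound 1 to compound 3 and a 12-fold lower number (1.09 log units; beyond the scatter) from compound 2 to compound 4, 6.0-fold (0.78 log units) apart, beyond the scatter of two such steps

Within the data shown here, what this does not show is which feature of the two cores sets the size of the step, as the cores differ in a way not broken down here and only two pairs are available, so neither a general rule for this exchange nor a reason for the gap can be drawn from them.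

On these data alone, it remains open whether other cores would follow the smaller step, the larger one, or neither. Also open, as far as these compounds go, is how the core of compound 2 would respond to an amine or a carboxylic acid carried on the pyridin-3-yl group, or to a longer chain in its place.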